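Swapping a Five-Membered Ring for a Six-Membered One

A few compounds are considered here, and "the series" means these few. Any claim that something is new, unique, unknown or untested is made for them only; others in the source may bear on it.

Compound 1 `Cc1ncc(-c2ccccc2NCC2=NCCN2)o1` carries a 2-methyl-1,3-oxazol-5-yl group on an aromatic carbon of the shared core. In a functional assay for activation of Alpha-1B adrenergic receptor (Homo sapiens), read by calcium flux (on this read-out higher numbers stand for an effect only at larger amounts of compound and lower numbers for an effect already at smaller amounts), compound 1 gives only a limit, < 5020 nM, so its place among the numbers is not fixed (the limit of < 5020 nM in this assay, at which 1 of the 3 values shown sits). Compound 2 `Cc1cc(-c2ccccc2NCC2=NCCN2)on1` gives 95.5 nM in this assay, and compound 3 `c1ccc(-c2cnccn2)c(NCC2=NCCN2)c1` gives 339 nM; the step of a 3.5-fold higher number from compound 2 to compound 3 (0.55 log units; beyond the scatter) is modest. Compound 4 `c1cnc(-c2ccccc2NCC2=NCCN2)nc1` differs from compound 1 in one place: pyrimidin-2-yl in place of 2-methyl-1,3-oxazol-5-yl on an aromatic carbon. With compound 1 at a limit, the steps a step that the limit leaves unreadable from compound 1 to compound 2 and a step that the limit leaves unreadable from compound 1 to compound 3 have no readable size and point in no direction. The nearest guide is compound 3 at 339 nM, whose pyrazin-2-yl group is likewise a six-membered ring with two nitrogens. Compound 4 is therefore expected near 350 nM, within 120 nM to 1200 nM. The step that the limit leaves unreadable from compound 1 to compound 4 is an estimate only.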

Compound 4, half-maximal effective concentration: 77.6 nM
Beside the measured number, compound 4's estimate is 4.5-fold (0.65 log units) above it; measured number outside the range, below it.
By their numbers in this assay, from the lowest: compounds 4 and 2 (each within the scatter of the next); then compound 3.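

Pyrimidin-2-yl in place of pyrazin-2-yl gives a 4.4-fold lower number from compound 3 to compound 4 (0.64 log units; beyond the scatter) in this assay, so at this position two six-membered rings with two hetero atoms each need not read alike. Pyrimidin-2-yl in place of 3-methyl-1,2-oxazol-5-yl gives a 1.2-fold lower number from compound 2 to compound 4 (0.09 log units; within the scatter), so among these compounds ring size alone does not set the number. The steps from compound 1 cannot be read, because its value is only a limit: the limit of < 5020 nM in this assay, at which 1 of the 4 values shown sits.

Still open, on these data alone, is how a pyridin-2-yl ring, with a single nitrogen, or a plain phenyl ring would read at this position in this assay. Also open, as far as these compounds go, is what an amine added to the pyrimidin-2-yl ring would do.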